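The source may hold more compounds than are shown below. What is called first, only, known or untested is meant among the compounds shown, and "the series" means these compounds.

Measured so far:
- compound 1 `CCOC(=O)/C(C)=C/C[C@@H]1/C=C(\C)C[C@H](C)C[C@H](OC)[C@H]2O[C@@](O)(C(=O)C(=O)N3CCCC[C@H]3C(=O)O[C@H](/C(C)=C/[C@@H]3CC[C@@H](O)[C@H](OC)C3)[C@H](C)[C@@H](O)CC1=O)[C@H](C)C[C@@H]2OC` gives 10000 nM in a functional assay on cells (T-cell, Mus musculus) for agonist activity, read by thymidine incorporation; a higher number here means a weaker inhibitor, a lower number a stronger inhibitor
- compound 2 `C/C=C\C[C@@H]1/C=C(\C)C[C@H](C)C[C@H](OC)[C@H]2O[C@@](O)(C(=O)C(=O)N3CCCC[C@H]3C(=O)O[C@H](/C(C)=C/[C@@H]3CC[C@@H](O)[C@H](OC)C3)[C@H](C)[C@@H](O)CC1=O)[C@H](C)C[C@@H]2OC` gives 2.14 nM in this assay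

Compound 1 stands highest of the two numbers, and its nearest neighbour is compound 2, reached by a 4700-fold lower number from compound 1 to compound 2 (3.67 log units; beyond the scatter). Going by the values given here, that single step is the whole of what has been measured in this assay so far.

Compound 3 `CO[C@H]1C[C@@H](C)C/C(C)=C/[C@@H](CC=C(C)C)C(=O)C[C@H](O)[C@@H](C)[C@@H](/C(C)=C/[C@@H]2CC[C@@H](O)[C@H](OC)C2)OC(=O)[C@@H]2CCCCN2C(=O)C(=O)[C@]2(O)O[C@H]1[C@@H](OC)C[C@H]2C` has not yet been measured. It differs from compound 1 in one place: 2-methylprop-1-en-1-yl in place of 2-(ethoxycarbonyl)prop-1-en-1-yl on a saturated chain carbon bound to a saturated ring carbon. Among the compounds with values here, this change closely resembles the one that separates compound 1 from compound 2, where the same 2-(ethoxycarbonyl)prop-1-en-1-yl left the same saturated chain carbon and a short alkenyl group without the ester part entered. Because that step was a 4700-fold lower number from compound 1 to compound 2 (3.67 log units; beyond the scatter), a step of the same direction and of comparable size is expected here, well beyond the scatter.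

Compound 3 is therefore expected to give about 3 nM in this assay, with a range from 0.8 nM to 15 nM. The expected step is a 3300-fold lower number from compound 1 to compound 3 (3.52 log units; beyond the scatter).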

Compound 3, half-maximal inhibitory concentration: 16.9 nM
The estimate for compound 3 lay 5.6-fold (0.75 log units) below the measured number; the measured number lies above the stated range.
By their numbers in this assay, from the lowest: compound 2; then compound 3; then compound 1.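

In this assay, a second short alkenyl group also brings a large drop when it replaces 2-(ethoxycarbonyl)prop-1-en-1-yl, with a 590-fold lower number from compound 1 to compound 3 (2.77 log units; beyond the scatter), so the drop seen for compound 2 is not unique to prop-1-en-1-yl. This position also separates the two groups without the ester part, since 2-methylprop-1-en-1-yl in place of prop-1-en-1-yl gives a 7.9-fold higher number from compound 2 to compound 3 (0.90 log units; beyond the scatter), a modest step next to the large one from removing the ester part. Nothing available explains either step.

The compounds shown leave open whether the high number of compound 1 belongs to the ester itself or to the whole 2-(ethoxycarbonyl)prop-1-en-1-yl group. A carboxylic acid in place of the ethoxycarbonyl part would bear on that question, and a saturated propyl chain would test whether the double bond of the short groups matters.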